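Cytotoxicity notes on the shared core: compound 3 to compound 4

The compounds below may be only part of what the source reports. "The series", "measured", "known", "first", "only" and "open" are said of these compounds alone.

Compound 1 `CNc1nc(C)c(-c2nc3ccccc3s2)c(N[C@@H]2C[C@H](CO)[C@@H](O)[C@H]2O)n1`: in an ADME assay on cells (Homo sapiens) for cytotoxicity, read by polymerase chain reaction, with a stated time of 3 days (on this read-out higher numbers stand for lower toxicity in this test and lower numbers for higher toxicity in this test), compound 1 gives > 25000 nM; this is a limit of the assay, not a number.
Compound 2 `Cc1nc(NC(C)C)nc(N[C@@H]2C[C@H](CO)[C@@H](O)[C@H]2O)c1-c1nc2ccccc2s1`: in this assay compound 2 gives 13000 nM.
Compound 3 `CCOCCNc1nc(C)c(-c2nc3ccccc3s2)c(N[C@@H]2C[C@H](CO)[C@@H](O)[C@H]2O)n1`: in this assay compound 3 gives 18000 nM.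

Compound 3 holds the higher of the two numbers available; compound 2 is nearest, and the gap between them is within the usual scatter, so no order is claimed. The remaining value is a limit (the limit of > 25000 nM in this assay, at which 1 of the 3 values shown sits).

The steps among the measured compounds all turn on the group carried by the nitrogen on the aromatic ring: an at least 1.9-fold lower number from compound 1 to compound 2 (0.28 log units; that floor lies within the scatter); an at least 1.3-fold lower number from compound 1 to compound 3 (0.14 log units; that floor lies within the scatter); a 1.4-fold higher number from compound 2 to compound 3 (0.14 log units; within the scatter). None of them reaches beyond the scatter.

Compound 4 `Cc1nc(Nc2nccs2)nc(N[C@@H]2C[C@H](CO)[C@@H](O)[C@H]2O)c1-c1nc2ccccc2s1` differs from compound 3 in one place: 1,3-thiazol-2-yl in place of 2-ethoxyethyl on a nitrogen on an aromatic ring. For the measured compounds named here, no measured step swaps a chain for an aromatic ring at that nitrogen; the measured steps only exchange one chain for another, and each stayed within scatter. The step of a 1.2-fold lower number from compound 3 to compound 4 (0.08 log units; within the scatter) is therefore expected to be small, with no direction that the data can support, and the range is kept wide to cover the unexplored exchange. For compound 4 in this assay the estimate is 15000 nM, expected to lie between 5000 nM and 30000 nM.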

Compound 4, half-maximal cytotoxic concentration: 15000 nM
Compound 4: the middle estimate sits on the measured number at the digits printed; the measured number falls inside the stated range.
By their numbers in this assay, from the lowest: compounds 2, 4 and 3 (each within the scatter of the next). At a limit, above all of these: compound 1.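

With 1,3-thiazol-2-yl on the nitrogen on the aromatic ring, compound 4 brings the first aromatic ring to a place that otherwise carries only chains, and the exchange leaves no readable mark in this assay: the comparison with the ether chain gives a 1.2-fold lower number from compound 3 to compound 4 (0.08 log units; within the scatter), and the comparison with the branched chain gives a 1.2-fold higher number from compound 2 to compound 4 (0.06 log units; within the scatter). Compounds 2, 3 and 4 therefore cannot be told apart in this test, so at this position a chain and this one five-membered aromatic ring with 2 hetero atoms read alike, and no order among them can be claimed. The comparison with the methyl compound yields only a floor, which also lies within the scatter: an at least 1.6-fold lower number from compound 1 to compound 4 (0.22 log units; that floor lies within the scatter); the value of compound 1 is a limit: the limit of > 25000 nM in this assay, at which 1 of the 4 values shown sits.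

On these data alone, it remains open whether any group on this nitrogen can move the number beyond the scatter, for example a chain ending in a carboxylic acid or a primary amine, or a phenyl ring. A single aromatic ring also cannot show whether other aromatic rings at this position would read the same way.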